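This account rests on a few compounds, and the source may have more. Where it says the series, first, only, none or still open, it means among the compounds named here.

Measured compounds in an assay on isolated protein for binding affinity to leukotriene B4 receptor 1 (Homo sapiens), tested at 1 uM; on this read-out higher numbers stand for more inhibition at the one concentration tested (going by the name of the read-out) and lower numbers for less inhibition:
- Compound 1, `CCCc1cc(C(C)=O)c(O)cc1OCCCCC#N`: 37%
- Compound 2, `CC(=O)c1cc(C(C)=O)c(OCCCCC#N)cc1O`: 0%
- Compound 3, `CCCc1cc(C(C)=O)c(O)cc1OCCCCCC(=O)O`: 24%

Compound 1 stands highest of the three numbers. Its nearest neighbour is compound 3, reached by a number 13 percentage points lower from compound 1 to compound 3 (beyond the scatter); its furthest is compound 2, reached by a number 37 percentage points lower from compound 1 to compound 2 (beyond the scatter).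

Compound 4, `CCCc1cc(C(C)=O)c(O)c(CCC)c1OCCCCC#N`, is not yet measured. It differs from compound 1 in one place: propyl in place of hydrogen on an aromatic carbon.

Neither measured step bears directly on this change. Within the data shown here, the step from compound 1 to compound 2 swaps one group for another at a carbon that already carries a group, and the step from compound 1 to compound 3 alters the end of the chain; no measured pair shows what happens when a group is added where compound 1 carries a hydrogen. The large drop in this assay on going to compound 2 only shows that the ring carbons matter, not in which direction an added propyl would move the number. The expectation for compound 4 is therefore a step from compound 1 of a number 2 percentage points lower from compound 1 to compound 4 (within the scatter), essentially no movement beyond the scatter, with wide uncertainty. The estimated value for compound 4 in this assay is 35%, between 8% and 62%.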

Compound 4, a percentage reported as inhibition, at one concentration (the size of the read-out at that concentration, not a potency): 0%
Compound 4: the middle estimate sits 35 percentage points above what was measured, outside the stated range (below it).
By their numbers in this assay, from the lowest: compounds 2 and 4 (each within the scatter of the next); then compound 3; then compound 1.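

In this assay, placing a propyl group on the aromatic carbon ortho to a 4-cyanobutoxy group and ortho to a hydroxy group, where compound 1 carries only a hydrogen, gives a number 37 percentage points lower from compound 1 to compound 4 (beyond the scatter). The earlier steps shown here changed groups already present, whereas this one shows that adding a group at this open ring carbon can by itself take the reading down to the 0% of compound 4. Nothing measured here explains this loss.

Propyl is the only group shown at this position besides hydrogen, so it remains open whether a methyl group, a fluorine atom or a methoxy group there would keep any of the inhibition. Going by these compounds, it is also open whether the loss would be the same in compound 3, which ends in a carboxylic acid.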